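Piperidinyl Substitution on the Aryl Ring of Compound 1

The source may report more compounds than this note shows. Statements on the series, on what has been measured and on what is new or still open speak of the compounds shown alone.

Compound 1, with the structure `CO[C@@]12CCN(C)C[C@H]1[C@H](c1ccccc1)C(C#N)=C(N)O2`, was examined in a functional assay (thoracic aorta, strain Wistar) for inhibition, with Rattus norvegicus as the target (a higher number here means a weaker inhibitor, a lower number a stronger inhibitor), where compound 1 gives 720000 nM. Two related compounds have been run in the same test. Compound 2, `CCN1CC[C@@]2(OC)OC(N)=C(C#N)[C@@H](c3ccccc3)[C@@H]2C1`, gives 680000 nM in this assay, and compound 3, `CCN1CC[C@@]2(OC)OC(N)=C(C#N)[C@@H](c3ccc(OC)cc3)[C@@H]2C1`, gives 680000 nM. All three numbers lie within the usual scatter of one another, so no ordering among them can be read from the data.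

The unmeasured compound 4 has the structure `CO[C@@]12CCN(C)C[C@H]1[C@H](c1ccc(N3CCCCC3)cc1)C(C#N)=C(N)O2`. It differs from compound 1 in one place: piperidin-1-yl in place of hydrogen on an aromatic carbon. Of the measured steps, the closer analogue is the aromatic substitution from compound 2 to compound 3, which gave no change at the digits printed from compound 2 to compound 3 (within the scatter). The change on the amine nitrogen, from compound 1 to compound 2, gave a 1.1-fold lower number from compound 1 to compound 2 (0.02 log units; within the scatter). Both steps are small, and neither concerns a piperidin-1-yl group, so the data give no sign that an aromatic substitution shifts the number in this assay.

Compound 4 is therefore expected to stay near compound 1, with an estimated step of a 1.0-fold lower number from compound 1 to compound 4 (0.01 log units; within the scatter). The estimate for compound 4 in this assay is 700000 nM, with a range from 250000 nM to 2000000 nM.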

Compound 4, half-maximal inhibitory concentration: 450000 nM
Beside the measured number, compound 4's estimate is 1.6-fold (0.19 log units) above it, within the range that was stated.
By their numbers in this assay, from the lowest: compounds 4, 2, 3 and 1 (each within the scatter of the next).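

In this assay, piperidin-1-yl in place of hydrogen on an aromatic carbon gives a 1.6-fold lower number from compound 1 to compound 4 (0.20 log units; within the scatter), so this position of the core of compound 1 takes a group bearing a six-membered non-aromatic ring without a step beyond the scatter. The earlier compounds had shown this position only with methoxy, in the step that gave no change at the digits printed from compound 2 to compound 3 (within the scatter), and on a core carrying ethyl rather than methyl at the amine nitrogen; compound 4 extends that observation to a different group, on the methyl-bearing core. Nothing measured here accounts for the size of this step, and no supporting data on the piperidin-1-yl group are available.

The compounds shown leave open whether any change at this aromatic carbon can move the number in this assay beyond the scatter, for instance a carboxylic acid, a primary amine or a longer chain in place of piperidin-1-yl. They also leave open whether piperidin-1-yl would give a similar step on the core of compound 2, which carries ethyl at the amine nitrogen.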